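Methoxy-to-hydroxy step in a bisamidine benzofuran series

The source may report more compounds than this note shows. Statements on the series, on what has been measured and on what is new or still open speak of the compounds shown alone.

Measured in an ADME assay on L6 cells (Rattus norvegicus) for cytotoxicity; a lower number here means a stronger inhibitor, a higher number a weaker inhibitor:
compound 1 `COc1cc(C(=N)N)ccc1-c1cc2cc(C(=N)N)ccc2o1` gives 157000 nM
compound 2 `COc1cc(C2=NCCN2)ccc1-c1cc2cc(C3=NCCN3)ccc2o1` gives 7400 nM
compound 3 `N=C(N)c1ccc(-c2cc3cc(C(=N)N)ccc3o2)c(O)c1` gives 33300 nM

Compound 3 differs from compound 1 by hydrogen in place of methyl on an oxygen on an aromatic ring, which gave a 4.7-fold lower number from compound 1 to compound 3 (0.67 log units; beyond the scatter). Compound 2 gives the lowest number of the three in this assay; how its core differs from that of compound 1 is not broken down here.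

Compound 4 `Oc1cc(C2=NCCN2)ccc1-c1cc2cc(C3=NCCN3)ccc2o1` is not yet measured. It differs from compound 2 by hydrogen in place of methyl on an oxygen on an aromatic ring, at a place described in the same words as for compound 1 and compound 3, so this is the same change. Among the compounds with values here, a step of similar direction and roughly similar size is expected from compound 2 to compound 4, namely a 3.7-fold lower number from compound 2 to compound 4 (0.57 log units; beyond the scatter), resting on the step from compound 1 to compound 3 a 4.7-fold lower number from compound 1 to compound 3 (0.67 log units; beyond the scatter) as the only measured instance. Compound 4 is therefore estimated at 2000 nM, with a range from 700 nM to 7000 nM.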

Compound 4, half-maximal inhibitory concentration: 150000 nM
For compound 4 the middle estimate is 75-fold (1.88 log units) below the measured one, and the stated range ends below it.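

In this assay, methoxy to hydroxy gave a 20-fold higher number from compound 2 to compound 4 (1.31 log units; beyond the scatter), opposite in direction to a 4.7-fold lower number from compound 1 to compound 3 (0.67 log units; beyond the scatter). The change therefore does not carry from one of these cores to the other, in direction or in size: the same change on two cores in this assay, a 4.7-fold lower number (0.67 log units; beyond the scatter) from compound 1 to compound 3 and a 20-fold higher number (1.31 log units; beyond the scatter) from compound 2 to compound 4, 96-fold (1.98 log units) apart, beyond the scatter of two such steps. With a single pair on each core, this shows that the result of the change cannot be assumed across the series, but it does not show which feature of the core decides the outcome or how a further core would respond.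

From the compounds shown here alone, it remains open how ethoxy or a longer chain in place of methoxy would read on either core. Also open, going by these compounds, is which part of the difference between the core of compound 1 and that of compound 2 sets the split.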